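A change from propoxy to benzyloxy at the limit

The source may hold more compounds than are shown below. What is called first, only, known or untested is meant among the compounds shown, and "the series" means these compounds.

In an ADME assay on BJ cells (Homo sapiens) for cytotoxicity, read by luminescence, with a stated time of 72 h (on this read-out higher numbers stand for an effect only at larger amounts of compound and lower numbers for an effect already at smaller amounts), compound 3 (`CCCOc1cccc(-c2[nH]c3cc(OC)ccc3c(=O)c2C(=O)OCC)c1`) gives > 21500 nM as a limit, not a number. Compound 1 (`CCOC(=O)c1c(-c2cc(F)cc(OC)c2)[nH]c2cc(OC)ccc2c1=O`) gives > 21500 nM as a limit too. Compound 2 (`CCOC(=O)c1c(-c2cccc(C)c2)[nH]c2cc(OC)ccc2c1=O`) also gives > 21500 nM as a limit. The series therefore stands at the limit of > 21500 nM in this assay, at which 3 of the 3 values shown sit, and has no measured number yet. Compound 4 (`CCOC(=O)c1c(-c2cccc(OCc3ccccc3)c2)[nH]c2cc(OC)ccc2c1=O`) carries phenyl in place of ethyl on a saturated chain carbon bound to an oxygen on an aromatic ring, turning propoxy into benzyloxy (phenyl in place of ethyl on a saturated chain carbon bound to an oxygen on an aromatic ring). Neither a step that the two limits leave unreadable from compound 2 to compound 3 nor a step that the two limits leave unreadable from compound 1 to compound 2 has a size that can be read, so they point in no direction. The expected a number no higher from compound 3 to compound 4 (the limit leaves the size open) in this assay is no step beyond the usual scatter, in either direction. For compound 4 the estimated value is 21500 nM with 12000 nM to 25000 nM as the expected range.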

Compound 4, half-maximal effective concentration: > 21500 nM
Compound 4: only a limit was reported (the forecaster's own chance of this, stated with the estimate: 85%); the middle value lies on the limit itself.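

Compound 2, compound 3 and compound 4 all give limits rather than numbers, and the steps to compound 4 cannot be read. From the compounds shown here alone, the actual value of each compound in this assay remains open.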